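Isobutyl for ethyl on the amine of compound 2

The source may report more compounds than this note shows. Statements on the series, on what has been measured and on what is new or still open speak of the compounds shown alone.

Compound 2 `CCc1cc(-c2noc(-c3cc(C)cc(CN(C)CC)c3)n2)cc(C)c1OC[C@@H](O)CNC(=O)CO` is known only by a limit in an ADME assay on liver (strain Wistar) for metabolic stability, with Liver microsome (Rattus norvegicus) as the target, read by LC-MS, using microsomes and NADPH, with a stated time of 15 min, tested at 1 uM; on this read-out lower numbers stand for slow clearance and higher numbers for fast clearance: compound 2 gives > 5000 mL.min-1.g-1, which is a limit of the assay and not a number (the limit of > 5000 mL.min-1.g-1 in this assay, at which 1 of the 3 values shown sits). Compound 1 `CCc1cc(-c2noc(-c3cc(C)nc(CN(C)CC(C)C)c3)n2)cc(C)c1OC[C@@H](O)CNC(=O)CO`, which carries the isobutyl(methyl)amino group on a different core, gives 1090 mL.min-1.g-1 in this assay. Compound 3 `CCCCN(C)Cc1cc(C)cc(-c2nc(-c3cc(C)c(OC[C@@H](O)CNC(=O)CO)c(CC)c3)no2)c1`, with the butyl chain, gives 7300 mL.min-1.g-1. Among the compounds with values here, the step that the limit leaves unreadable from compound 2 to compound 3 cannot be read in size, and no other measured step bears directly on the change considered here.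

Compound 4 `CCc1cc(-c2noc(-c3cc(C)cc(CN(C)CC(C)C)c3)n2)cc(C)c1OC[C@@H](O)CNC(=O)CO` differs from compound 2 by isopropyl in place of methyl on a saturated chain carbon bound to an amine nitrogen. With only a limit as the starting point, the expected step that the limit leaves unreadable from compound 2 to compound 4 cannot be read against the scatter, and the value of compound 4 is expected to stay in the region of fast clearance where compounds 2 and 3 sit. The estimate for compound 4 in this assay is 7000 mL.min-1.g-1, with a range from 3000 mL.min-1.g-1 to 16000 mL.min-1.g-1.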

Compound 4, intrinsic clearance in microsomes: 740 mL.min-1.g-1
Compound 4: the middle estimate sits 9.5-fold (0.98 log units) above what was measured; the measured number lies below the stated range.
By their numbers in this assay, from the lowest: compounds 4 and 1 (each within the scatter of the next); then compound 3.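

Compound 2 stands at a limit of the assay and not at a number, in this assay: the limit of > 5000 mL.min-1.g-1 in this assay, at which 1 of the 4 values shown sits.

Isobutyl for ethyl on the amine gives an at least 6.7-fold lower number from compound 2 to compound 4 (0.82 log units; beyond the scatter), so this position can bring clearance down from the limit, which the earlier compounds could not show. Butyl to isobutyl gives a 9.9-fold lower number from compound 3 to compound 4 (0.99 log units; beyond the scatter), so among the compounds with this core, the branched chain goes with the lower number and the straight butyl chain does not.

As far as these compounds go, the step from ethyl to butyl cannot be read, so what lengthening the chain does on its own stays open. Also open, from the compounds shown here alone, is whether the lower number holds for other branched groups on this amine, such as cyclopropylmethyl or neopentyl.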